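Aromatic group swap from compound 2 to compound 3

The source may report more compounds than this note shows. Statements on the series, on what has been measured and on what is new or still open speak of the compounds shown alone.

In a functional assay on HL-60 cells (Homo sapiens) for inhibition (on this read-out higher numbers stand for weaker inhibition and lower numbers for stronger inhibition), compound 1 (`OC[C@H]1OC(n2cnc3c(-c4ccco4)ncnc32)[C@H](O)[C@@H]1O`) gives 2700 nM and compound 2 (`Cc1ccsc1-c1ncnc2c1ncn2C1O[C@H](CO)[C@@H](O)[C@H]1O`) gives 4500 nM. Going by the values given here, compound 2 therefore stands level with compound 1, the only other measured compound, as the two values lie within the scatter of each other. Compound 3 (`OC[C@H]1OC(n2cnc3c(-c4ccc(F)cc4)ncnc32)[C@H](O)[C@@H]1O`) has 4-fluorophenyl in place of 3-methylthiophen-2-yl on an aromatic carbon of a six-membered aromatic ring with 2 nitrogen (4-fluorophenyl in place of 3-methylthiophen-2-yl on an aromatic carbon). Among the compounds with values here, one measured step bears on this change: a 1.7-fold higher number from compound 1 to compound 2 (0.22 log units; within the scatter), also an exchange of the aromatic group on the shared core. It is a single step, and no six-membered aromatic group has yet been measured in this series, so the guidance is thin. No step beyond the scatter is expected in this assay, and no direction can be argued. The expected change is a 1.1-fold higher number from compound 2 to compound 3 (0.05 log units; within the scatter). For compound 3 the estimate is 5000 nM, with an expected range of 1500 nM to 16000 nM.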

Compound 3, half-maximal inhibitory concentration: 6300 nM
For compound 3 the middle estimate is 1.3-fold (0.10 log units) below the measured one, and the stated range covers the measured number.
By their numbers in this assay, from the lowest: compounds 1, 2 and 3 (each within the scatter of the next, the first and the last beyond it).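

In this assay the exchange of 3-methylthiophen-2-yl for 4-fluorophenyl on this aromatic carbon gives a 1.4-fold higher number from compound 2 to compound 3 (0.15 log units; within the scatter) and so shows no change that can be told apart, even though a six-membered aromatic ring of carbon only now replaces a five-membered one. Against furan-2-yl the same group gives a 2.3-fold higher number from compound 1 to compound 3 (0.37 log units; beyond the scatter) towards weaker inhibition, the first step in the series to pass the scatter, though only a modest one, while compound 2 stays within the scatter of both other compounds. Open, from the compounds shown here alone, is whether an amine or a carboxylic acid on this aromatic carbon would move the number further than these aromatic groups do. Also open, going by these compounds, is how a plain phenyl compares with 4-fluorophenyl here. Nothing at hand gives a reason for the gap between furan-2-yl and 4-fluorophenyl.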